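From a methoxy group to a hydroxyl in compound 4

The source may hold more compounds than are shown below. What is called first, only, known or untested is meant among the compounds shown, and "the series" means these compounds.

In a functional assay on HCT-116 cells (Homo sapiens) for antiproliferative activity, read by CellTiter-Glo, with a stated time of 72 h (on this read-out lower numbers stand for stronger inhibition and higher numbers for weaker inhibition), three compounds have these values

Compound 1 `O=C(NO)c1ccc(/C=C/c2ccnc(-c3cc(F)ccc3O)c2)cc1` gives 2040 nM
Compound 2 `O=C(NO)c1ccc(/C=C/c2ccnc(-c3ccccc3O)c2)cc1` gives 1450 nM
Compound 3 `COc1ccccc1-c1cc(/C=C/c2ccc(C(=O)NO)cc2)ccn1` gives 8440 nM

Compound 3 has the highest number of the three. Compound 4 `O=C(NO)c1ccc(/C=C/c2ccnc(-c3cccc(O)c3)c2)cc1` carries 3-hydroxyphenyl in place of 2-methoxyphenyl on an aromatic carbon next to the ring nitrogen 3-hydroxyphenyl in place of 2-methoxyphenyl on an aromatic carbon as its change. The closest evidence is the step of a 5.8-fold higher number from compound 2 to compound 3 (0.76 log units; beyond the scatter) with methyl in place of hydrogen on an oxygen, and the step of a 4.1-fold higher number from compound 1 to compound 3 (0.62 log units; beyond the scatter) points the same way. The step of a 1.4-fold lower number from compound 1 to compound 2 (0.15 log units; within the scatter) adds little. For the measured compounds named here, no measured compound carries the 3-hydroxyphenyl group, so the size remains uncertain. The expected step is a 2.8-fold lower number from compound 3 to compound 4 (0.45 log units; beyond the scatter) toward a lower number in this assay and somewhat smaller than those two. Compound 4 is estimated at 3000 nM with 1000 nM to 8500 nM as the expected range.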

Compound 4, half-maximal inhibitory concentration: 1610 nM
The estimate for compound 4 lay 1.9-fold (0.27 log units) above the measured number, within the range that was stated.
By their numbers in this assay, from the lowest: compounds 2, 4 and 1 (each within the scatter of the next); then compound 3.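

In this assay, 3-hydroxyphenyl in place of 2-methoxyphenyl on the aromatic carbon next to the ring nitrogen gives a 5.2-fold lower number from compound 3 to compound 4 (0.72 log units; beyond the scatter), so a hydroxyl on the 3-hydroxyphenyl group serves here as well as on the 2-hydroxyphenyl group. The comparisons with the other hydroxyl compounds, a 1.1-fold higher number from compound 2 to compound 4 (0.05 log units; within the scatter) and a 1.3-fold lower number from compound 1 to compound 4 (0.10 log units; within the scatter), leave these three indistinguishable, and only the methoxy compound 3 stands apart. No evidence here offers a reason for this.

The compounds shown leave open how 3-methoxyphenyl would compare with 3-hydroxyphenyl at this position. They also leave open whether an amine or a carboxylic acid on that phenyl ring could replace the hydroxyl.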